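The source may report more compounds than this note shows. Statements on the series, on what has been measured and on what is new or still open speak of the compounds shown alone.

Compound 1 `O=c1cc(OCC(O)CNC2CC2)c2ccccc2o1` bears a cyclopropylamino group. In an ADME assay on Vero cells (Chlorocebus sabaeus) for cytotoxicity, read by fluorescence and resazurin assay, with a stated time of 72 h (a lower number here means that less compound is tolerated, a higher number that more compound is tolerated), compound 1 gives only the limit > 100000 nM, not a number. Compound 2 `CCCCCCCC/C=C/CCCCCCCCNCC(O)COc1cc(=O)oc2ccccc12` likewise reaches only the limit, > 100000 nM. Compound 3 `CCCCCCCCCCCCNCC(O)COc1cc(=O)oc2ccccc12` also sits at the limit, > 100000 nM. Going by the values given here, the single step between measured compounds, a step that the two limits leave unreadable from compound 2 to compound 3, cannot be read because of the limit of > 100000 nM in this assay, at which 3 of the 3 values shown sit. Compound 4 `CN1CCN(CC(O)COc2cc(=O)oc3ccccc23)CC1` differs from compound 1 by 4-methylpiperazin-1-yl in place of cyclopropylamino on a saturated chain carbon, two bonds along the chain from an oxygen on a saturated carbon. Among the compounds with values here, no measured step bears directly on this change, and every value seen so far rests at the limit, so no step beyond the scatter is expected in this assay; that expectation amounts to an estimated a number no higher from compound 1 to compound 4 (the limit leaves the size open). Compound 4 is therefore expected at 100000 nM, within a range of 50000 nM to 200000 nM.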

Compound 4, half-maximal cytotoxic concentration: > 100000 nM
Compound 4 ended at the assay's limit (the forecaster's own chance of this, stated with the estimate: 85%); the middle value lies on the limit itself.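

Compound 1 and compound 4 both stop at a limit rather than a number, so no step can be read between them because of this: the limit of > 100000 nM in this assay, at which 4 of the 4 values shown sit. The compounds shown leave open what concentration of any of them would reach half-maximal cytotoxicity in this assay, and whether changing the group alters it.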